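Replacing a hydroxy group on a carbonyl carbon

This account rests on a few compounds, and the source may have more. Where it says the series, first, only, none or still open, it means among the compounds named here.

compound 1 `CC(=O)SCCC(CCCCC(=O)O)SC(C)=O` gives 11%
compound 2 `COc1ccc(NC(=O)CCCCC(S)CCS)cc1` gives 23.5%

Going by the values given here, in a functional assay on NCI-H460 cells (Homo sapiens) for inhibition, read by MTT assay, with a stated time of 24 h, tested at 100 ug/mL (on this read-out higher numbers stand for more inhibition of growth at the one concentration tested and lower numbers for less inhibition of growth), compound 1 gives 11% and stands lower of the two compounds measured so far. Compound 2 reaches 23.5% and that gap lies beyond the usual scatter of repeated measurements.

The next compound is compound 3 `CC(=O)SCCC(CCCCC(=O)Nc1ccc(Cl)cc1)SC(C)=O` which differs from compound 1 at one place, by (4-chlorophenyl)amino in place of hydroxy on a carbonyl carbon and nothing else. In words, (4-chlorophenyl)amino stands in place of hydroxy on a carbonyl carbon.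

Among the compounds with values here, no measured pair shows this change on its own, so the data do not fix its size. Within the data shown here, the only guide is that compound 2 at 23.5% sits higher than compound 1 does. A moderate upward move in this assay is therefore expected, though it may barely clear the scatter. The expected step of a number 17 percentage points higher from compound 1 to compound 3 (beyond the scatter) is an estimate with wide margins. For compound 3 the estimated value is 28% with an expected range from 12% to 50% once it is measured.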

Compound 3, percent growth inhibition at one concentration: 47.3%
For compound 3 the middle estimate is 19.3 percentage points below the measured one, and the stated range covers the measured number.
By their numbers in this assay, from the lowest: compound 1; then compound 2; then compound 3.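

The carbonyl carbon of compound 1 proves to be a position where the read-out responds strongly to change. In this assay, putting (4-chlorophenyl)amino in place of hydroxy gives a number 36.3 percentage points higher from compound 1 to compound 3 (beyond the scatter), a large step that lies beyond the usual scatter. The earlier values could not isolate this, as compound 1 and compound 2 differ in more than one place, whereas here the rest of the molecule stays the same and a single hydroxy gives way to a much larger group with a six-membered aromatic ring. Nothing measured here explains why growth inhibition rises with this change.

Going by these compounds alone, the single step changes several things at once, so it leaves open whether the rise depends on the nitrogen, the aromatic ring or the chlorine. A plain phenylamino group or a small methylamino group on the same carbonyl carbon would help separate these parts, and a methoxy ester there would show whether a nitrogen is needed at all.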